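The source may report more compounds than this note shows. Statements on the series, on what has been measured and on what is new or still open speak of the compounds shown alone.

Measured compounds:

Compound 1, `S=C(N/N=C/c1cccs1)Nc1ccccc1`. In a functional assay on NCI-H460 cells (Homo sapiens) for inhibition, read by sulforhodamine B assay, with a stated time of 48 h (on this read-out lower numbers stand for stronger inhibition of growth and higher numbers for weaker inhibition of growth), compound 1 gives > 100000 nM, which is a limit of the assay rather than a number.
Compound 2, `CCc1ccc(NC(=S)N/N=C/c2cccs2)cc1`. In this assay compound 2 gives > 100000 nM, again a limit of the assay.
Compound 3, `S=C(N/N=C/c1cccs1)Nc1ccc(Cl)cc1`. In this assay compound 3 gives > 100000 nM, also a limit of the assay.

Compound 3 therefore stands at the limit, and it stands there together with the other two, since (the limit of > 100000 nM in this assay, at which 3 of the 3 values shown sit). Because all three values are limits, the three steps between them cannot be sized: a step that the two limits leave unreadable from compound 1 to compound 2, a step that the two limits leave unreadable from compound 1 to compound 3 and a step that the two limits leave unreadable from compound 2 to compound 3 are all unreadable. The two steps that touch the same aromatic carbon as the change now considered, from compound 1 to compound 3 and from compound 2 to compound 3, thus give no readable size either.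

Compound 4 is `S=C(N/N=C/c1cccs1)Nc1ccc(Br)cc1`. It differs from compound 3 by bromo in place of chloro on an aromatic carbon. With every measured compound sitting at the limit and no readable step to lean on, the step from compound 3 to compound 4 is expected to be a number no higher from compound 3 to compound 4 (the limit leaves the size open), that is, no change beyond the scatter, and compound 4 is expected to remain at the limit as well. The estimate for compound 4 in this assay is 100000 nM, with a range from 50000 nM to 300000 nM.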

Compound 4, concentration for 50% growth inhibition: 4700 nM
The estimate for compound 4 lay 21-fold (1.33 log units) above the measured number; the measured number lies below the stated range.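

In this assay, this place on the ring, para to a large group, turns out to be able to move the read-out: bromo in place of chloro gives an at least 21-fold lower number from compound 3 to compound 4 (1.32 log units; beyond the scatter), so the choice between these two groups matters here, even though neither adds a ring, a hydrogen-bond donor or acceptor, or a charge. The bromo compound also stands apart from the ethyl and unsubstituted compounds, with an at least 21-fold lower number from compound 2 to compound 4 (1.32 log units; beyond the scatter) and an at least 21-fold lower number from compound 1 to compound 4 (1.32 log units; beyond the scatter), so among these four compounds, only bromo at this place gives a growth-inhibition number. The steps among compound 1, compound 2 and compound 3 still cannot be read, and those three compounds remain without a number: the limit of > 100000 nM in this assay, at which 3 of the 4 values shown sit.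

From the compounds shown here alone, how iodo, methoxy or an amine at this same place would compare with bromo stays open, as does whether bromo would have a similar effect elsewhere on the ring. Going by these compounds, the full size of the three new steps also stays open: the compound at the start of each one stands at a limit of the assay.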